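From a dimethylmorpholine to a two-ring group

The source may hold more compounds than are shown below. What is called first, only, known or untested is meant among the compounds shown, and "the series" means these compounds.

Three compounds share one core and differ in the ring group attached to it: compound 1 `CN1CCN(c2nc3c(cc2[N+](=O)[O-])c(=O)c(C(=O)O)cn3C2CC2)CC1c1ccccc1`, compound 2 `CC1CN(c2nc3c(cc2[N+](=O)[O-])c(=O)c(C(=O)O)cn3C2CC2)CC(C)O1` and compound 3 `CCN(CC)C(=O)C1CCCN(c2nc3c(cc2[N+](=O)[O-])c(=O)c(C(=O)O)cn3C2CC2)C1`. In an ADME assay on Vero cells (Chlorocebus sabaeus) for cytotoxicity, read by MTT assay, with a stated time of 72 h (on this read-out higher numbers stand for weaker inhibition and lower numbers for stronger inhibition), compound 1 gives 139000 nM as a true number, the only one so far.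

Compound 2 shows > 160000 nM in this assay and this is a limit of the assay, not a number. Compound 3 shows > 136000 nM in this assay and this too is a limit. Compound 2 therefore has no exact place among the three results.

Compound 4 `O=C(O)c1cn(C2CC2)c2nc(N3CCC4(CC3)OCCO4)c([N+](=O)[O-])cc2c1=O` keeps the shared core and changes one group on an aromatic carbon: a group of 10 heavy atoms (7 carbon, 1 nitrogen, 2 oxygen; one five-membered non-aromatic ring with 2 hetero atoms, one six-membered non-aromatic ring with 1 hetero atom) in place of a group of 8 heavy atoms (6 carbon, 1 nitrogen, 1 oxygen; one six-membered non-aromatic ring with 2 hetero atoms), on an aromatic carbon. Within the data shown here, no two measured compounds differ in just one place, so no measured step guides this change. Among the measured compounds shown here, the best guide is compound 1 at 139000 nM in this assay as the one number available, and it lies on the weak side of this read-out.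

A small step is expected, an at least 1.0-fold lower number from compound 2 to compound 4 (0.02 log units; that floor lies within the scatter) and no larger than the usual scatter, with no clear direction. For compound 4 the estimated value is 150000 nM with an expected range from 80000 nM to 200000 nM in this assay.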

Compound 4, half-maximal inhibitory concentration: 150000 nM
Estimate against measurement, compound 4: no gap at the digits printed; the range from low to high includes it.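

At this position, on an aromatic carbon next to the ring nitrogen, in this assay compound 4 gives 150000 nM as the second true number among the ring groups shown, and the first for a group with two rings. The change from 2,6-dimethylmorpholin-4-yl to this two-ring group, which adds a five-membered non-aromatic ring with 2 hetero atoms, reads as an at least 1.0-fold lower number from compound 2 to compound 4 (0.02 log units; that floor lies within the scatter) and so shows no clear change. Compound 2 holds a limit of the assay and not a number, so this step has only a floor and no true size: the limit of > 160000 nM in this assay, at which 1 of the 4 values shown sits.

The compounds shown leave open whether a group without a ring at this position, such as a simple amine or a longer carbon chain, would give a clearly different number in this assay and bring it nearer the strong side of the read-out. Also open, as far as these compounds go, is whether a six-membered ring carrying a free carboxylic acid in place of the five-membered ring of compound 4 would read any differently.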